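The compounds below may be only part of what the source reports. "The series", "measured", "known", "first", "only" and "open" are said of these compounds alone.

Measured so far:
- compound 1, `C=CCN(CCCC(=O)O)C(=O)/C(C)=C/c1ccc(C(=O)Oc2ccc(C(=N)N)cc2)cc1`, in an in vitro ADME assay on a cell-free system (plasma) for pharmacokinetics; on this read-out higher numbers stand for a longer-lived compound and lower numbers for a shorter-lived compound: > 1 h
- compound 2, `C/C(=C\c1ccc(C(=O)Oc2ccc(C(=N)N)cc2)cc1)C(=O)N(CC(=O)O)C1CCCC1`: 0.383 h
- compound 3, `C=CCN(CCCC(=O)OCC)C(=O)/C(C)=C/c1ccc(C(=O)Oc2ccc(C(=N)N)cc2)cc1`: < 0.0167 h

Compound 3 stands at a limit of this assay, namely (the limit of < 0.0167 h in this assay, at which 1 of the 3 values shown sits), so only a bound is known for it. Compound 1 likewise sits at a limit, (the limit of > 1 h in this assay, at which 1 of the 3 values shown sits). Compound 4, `C=CCN(CCC(=O)O)C(=O)/C(C)=C/c1ccc(C(=O)Oc2ccc(C(=N)N)cc2)cc1`, differs from compound 3 by carboxy in place of (ethoxycarbonyl)methyl on a saturated chain carbon, two bonds along the chain from an amide-type nitrogen. The step that bears on this change is an at least 59-fold lower number from compound 1 to compound 3 (1.77 log units; beyond the scatter), a large fall upon putting ethyl on the oxygen; the step of an at least 2.6-fold lower number from compound 1 to compound 2 (0.41 log units; beyond the scatter) concerns another part of the chain and says less here. Going from compound 3 to compound 4 removes that ethyl again, so a large rise is expected, an at least 89-fold higher number from compound 3 to compound 4 (1.95 log units; beyond the scatter). Compound 4 is therefore estimated at 1.5 h, in the range 0.4 h to 6 h.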

Compound 4, half-life: 0.783 h
Estimate against measurement, compound 4: 1.9-fold (0.28 log units) above, and the stated range covers the measured number.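

Compound 3 and compound 1 each stand at a limit of this assay, so the steps from them are bounds only. Even so, 2-carboxyethyl in place of 3-(ethoxycarbonyl)propyl gives an at least 46-fold higher number from compound 3 to compound 4 (1.67 log units; beyond the scatter), and the change of both nitrogen groups gives a 2.0-fold higher number from compound 2 to compound 4 (0.31 log units; beyond the scatter). Carboxy in place of carboxymethyl gives an at least 1.2-fold lower number from compound 1 to compound 4 (0.10 log units; that floor lies within the scatter), so a cost of the shorter chain is neither shown nor excluded.

Open, on these data alone, is how an ethyl ester on the 2-carboxyethyl chain would fare, which would separate ester from chain length. As far as these compounds go, a primary amide in place of the carboxy, or a longer chain, also remains open.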